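Adding Chloro to Compound 1: A Small Structural Step

The source may report more compounds than this note shows. Statements on the series, on what has been measured and on what is new or still open speak of the compounds shown alone.

Compound 1 `c1ccc(-c2cc3n(n2)CCCC3)cc1` gives 1900 nM in a functional assay on HEK293 cells for negative allosteric modulation of metabotropic glutamate receptor 5 (Rattus norvegicus), read by FLIPR and calcium flux, with a stated time of 170 s; on this read-out higher numbers stand for weaker inhibition and lower numbers for stronger inhibition. Only compound 2 `Clc1ccccc1-c1cc2n(n1)CCCC2` has been measured beside it, and compound 2 gives 2650 nM, a number within the scatter of compound 1. Compound 3 `Clc1ccc(-c2cc3n(n2)CCCC3)cc1` differs from compound 1 by chloro in place of hydrogen on an aromatic carbon. For the measured compounds named here, the single measured step that bears on this change, a 1.4-fold higher number from compound 1 to compound 2 (0.14 log units; within the scatter), also set chloro in place of hydrogen on an aromatic carbon and stayed within the scatter. For compound 3 in this assay no step beyond the scatter is therefore expected, a 1.1-fold higher number from compound 1 to compound 3 (0.02 log units; within the scatter). The estimate for compound 3 is 2000 nM, expected between 700 nM and 5700 nM.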

Compound 3, half-maximal inhibitory concentration: 4230 nM
Beside the measured number, compound 3's estimate is 2.1-fold (0.33 log units) below it, and the stated range covers the measured number.
By their numbers in this assay, from the lowest: compounds 1, 2 and 3 (each within the scatter of the next, the first and the last beyond it).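

With chloro on an aromatic carbon, para to a group of 9 heavy atoms, the change brings a 2.2-fold higher number from compound 1 to compound 3 (0.35 log units; beyond the scatter) in this assay. This is the first step of this change shown to pass beyond the scatter, though only modestly, so at this place chloro gives weaker inhibition than hydrogen. Nothing measured here gives a reason for this step.

The compounds shown leave open how other groups at this same carbon would read, such as fluoro, methoxy, an amine or a carboxylic acid. They also leave open whether a group larger than chloro would take the number higher still.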